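The source may report more compounds than this note shows. Statements on the series, on what has been measured and on what is new or still open speak of the compounds shown alone.

Of the compounds shown here, three have so far been measured in a functional assay on K562 cells (Homo sapiens) for cytotoxicity, read by sulforhodamine B assay, with a stated time of 48 h; on this read-out higher numbers stand for weaker inhibition of growth and lower numbers for stronger inhibition of growth. Compound 1 `ClCc1ccccc1Cn1cnc2c(Cl)nc(Cl)nc21` gives 150 nM in this assay. Compound 2 `ClCc1ccccc1Cn1cnc2c(Cl)ncnc21` gives 1200 nM in this assay. Compound 3 `ClCc1cccc(Cn2cnc3ncnc(Cl)c32)c1` gives 16600 nM in this assay, the highest of the three numbers. Compound 1 differs from compound 2 only by chloro in place of hydrogen on an aromatic carbon, and this single change produced an 8.0-fold lower number from compound 2 to compound 1 (0.90 log units; beyond the scatter). Compound 3 is built from the same atoms as compound 2, joined differently; the difference between the two cores is not broken down here.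

Compound 4 `ClCc1cccc(Cn2cnc3nc(Cl)nc(Cl)c32)c1` has not yet been measured. It differs from compound 3 by chloro in place of hydrogen on an aromatic carbon, which is the same change as that made from compound 2 to compound 1, at a place described in the same words. Going by the values given here, only one earlier instance of this change exists, so the expectation rests on it alone. From compound 3 to compound 4 a step of an 8.3-fold lower number from compound 3 to compound 4 (0.92 log units; beyond the scatter) is expected in this assay, because the earlier instance gave an 8.0-fold lower number from compound 2 to compound 1 (0.90 log units; beyond the scatter). Compound 4 is therefore estimated at 2000 nM in this assay, with a likely range from 700 nM to 6000 nM.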

Compound 4, concentration for 50% growth inhibition: 1410 nM
Estimate against measurement, compound 4: 1.4-fold (0.15 log units) above; the measured number falls inside the stated range.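

Replacing the hydrogen between two ring nitrogen atoms with a chloro group gave a step of a 12-fold lower number from compound 3 to compound 4 (1.07 log units; beyond the scatter) in this assay, and the change carried over from one core to the other at much the same size: the same change on two cores in this assay, an 8.0-fold lower number (0.90 log units; beyond the scatter) from compound 2 to compound 1 and a 12-fold lower number (1.07 log units; beyond the scatter) from compound 3 to compound 4, 1.5-fold (0.17 log units) apart, within the scatter of two such steps

Within these four compounds, then, the step held on both cores, even though the atoms of those cores are joined differently. Going by these compounds alone, this rests on only two pairs of compounds in a single assay, so it sets no rule for other cores and does not explain why the chloro group lowers the number.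

The compounds shown leave open whether an amine, a methoxy group or a bromo group on that same carbon would lower the number as chloro does. They also leave open whether the step would persist with an amine in place of the other chloro group on that ring.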